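Combining Two Single Changes on a Shared Core

A few compounds are considered here, and "the series" means these few. Any claim that something is new, unique, unknown or untested is made for them only; others in the source may bear on it.

Compound 1 `Cc1cc(=O)n(-c2ccccc2C(F)(F)F)nc1C(=O)Nc1ccc(Oc2ncnc3sccc23)cc1` is the reference point of this set. In a functional assay on MCF7 cells (Homo sapiens) for cytotoxicity, read by MTT assay, with a stated time of 72 h (a lower number here means a stronger inhibitor, a higher number a weaker inhibitor), compound 1 returns only a limit, > 40000 nM. Compound 2 `Cc1cc(=O)n(-c2ccc(Br)cc2F)nc1C(=O)Nc1ccc(Oc2ncnc3sccc23)cc1` carries 4-bromo-2-fluorophenyl in place of 2-(trifluoromethyl)phenyl on an aromatic nitrogen, and in this assay compound 2 gives 15200 nM; this amounts to an at least 2.6-fold lower number from compound 1 to compound 2 (0.42 log units; beyond the scatter), a step whose size rests on (the limit of > 40000 nM in this assay, at which 1 of the 3 values shown sits). Compound 3 `Cc1cc(=O)n(-c2ccccc2C(F)(F)F)nc1C(=O)Nc1ccc(Oc2ncnc3sccc23)c(F)c1` differs from compound 1 by fluoro in place of hydrogen on an aromatic carbon, and in this assay compound 3 gives 13800 nM, which is an at least 2.8-fold lower number from compound 1 to compound 3 (0.46 log units; beyond the scatter). Compound 2 and compound 3 sit within the scatter of one another. The unmeasured compound 4 `Cc1cc(=O)n(-c2ccc(Br)cc2F)nc1C(=O)Nc1ccc(Oc2ncnc3sccc23)c(F)c1` is related to compound 3 by 4-bromo-2-fluorophenyl in place of 2-(trifluoromethyl)phenyl on an aromatic nitrogen, the same change already seen from compound 1 to compound 2, occurring twice among these four compounds. Since that earlier step was an at least 2.6-fold lower number from compound 1 to compound 2 (0.42 log units; beyond the scatter) and started from a limit, its true size is not known, and whether it carries over onto the core of compound 3 has not been tested. Compound 4 is therefore expected to show a step of a 2.3-fold lower number from compound 3 to compound 4 (0.36 log units; beyond the scatter) in this assay. The estimate for compound 4 in this assay is 6000 nM, with an expected range from 2500 nM to 15000 nM.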

Compound 4, half-maximal inhibitory concentration: 13300 nM
Beside the measured number, compound 4's estimate is 2.2-fold (0.35 log units) below it, within the range that was stated.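

In this assay, placing 4-bromo-2-fluorophenyl on the aromatic nitrogen of the fluoro-bearing core gives a 1.0-fold lower number from compound 3 to compound 4 (0.02 log units; within the scatter), and adding the fluoro to the core that already carries 4-bromo-2-fluorophenyl gives a 1.1-fold lower number from compound 2 to compound 4 (0.06 log units; within the scatter). On this core, then, neither single change moves the number beyond the scatter, but this does not establish that the exchange on the aromatic nitrogen behaves differently on the two cores: the same change on two cores in this assay, an at least 2.6-fold lower number (0.42 log units; beyond the scatter) from compound 1 to compound 2 and a 1.0-fold lower number (0.02 log units; within the scatter) from compound 3 to compound 4; the limit leaves it open whether they differ. The same holds for the fluoro change: the same change on two cores in this assay, an at least 2.8-fold lower number (0.46 log units; beyond the scatter) from compound 1 to compound 3 and a 1.1-fold lower number (0.06 log units; within the scatter) from compound 2 to compound 4; the limit leaves it open whether they differ.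

From the compounds shown here alone, whether a plain phenyl or a 4-methoxyphenyl on the aromatic nitrogen would give a number apart from those of compound 2, compound 3 and compound 4 remains open, as does the effect of an amine or a carboxylic acid in place of the methyl group. Also open, going by these compounds, is the true size of both steps from compound 1, whose reading is only a limit.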